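The source may report more compounds than this note shows. Statements on the series, on what has been measured and on what is new or still open speak of the compounds shown alone.

Working notes on the series, read in a functional assay on HT-29 cells (Homo sapiens) for antiproliferative activity, read by XTT assay, with a stated time of 72 h; a lower number here means a stronger inhibitor, a higher number a weaker inhibitor. Compound 1 (`C=C(C)CCC[C@]1(C)C2=CCC[C@](C)(CC(=O)c3ccoc3)[C@H]2CC[C@H]1C`) gives > 100000 nM, which is a limit of the assay and not a number. Compound 2 (`CC(C)=CCC[C@]1(C)C2=CCC[C@](C)(CC(=O)c3ccoc3)[C@H]2CC[C@H]1C`) gives 82300 nM. Compound 3 (`C=C(C)CC[C@]1(C)C2=CCC[C@](C)(C[C@@H](OC(C)=O)C3=CC(=O)OC3O)[C@H]2CC[C@H]1C`) gives 4800 nM, and it differs from compound 1 in more than one place.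

Compound 4 (`C=C(C)CCC[C@]1(C)C2=CCC[C@](C)(C[C@@H](O)c3ccoc3)[C@H]2CC[C@H]1C`) has (furan-3-yl)(hydroxy)methyl in place of (furan-3-yl)carbonyl on a saturated chain carbon bound to a saturated ring carbon.

Among the compounds with values here, only one measured step exists, an at least 1.2-fold lower number from compound 1 to compound 2 (0.08 log units; that floor lies within the scatter), and it concerns a different group, so no measured step bears directly on this change. Compound 2, which keeps the carbonyl, at 82300 nM is the nearest guide and suggests that compound 4 will also stay weak in this assay. A small move to a lower number is expected, with an estimated at least 1.6-fold lower number from compound 1 to compound 4 (0.22 log units; that floor lies within the scatter), and a reading at the limit remains possible. For compound 4 the estimated value is 60000 nM, with an expected range of 20000 nM to 150000 nM.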

Compound 4, half-maximal inhibitory concentration: 63100 nM
Compound 4: the middle estimate sits 1.1-fold (0.02 log units) below what was measured, within the range that was stated.
By their numbers in this assay, from the lowest: compound 3; then compounds 4 and 2 (each within the scatter of the next). At a limit, above all of these: compound 1.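

In this assay, (furan-3-yl)(hydroxy)methyl in place of (furan-3-yl)carbonyl on a saturated chain carbon bound to a saturated ring carbon gives an at least 1.5-fold lower number from compound 1 to compound 4 (0.19 log units; that floor lies within the scatter); this is the only step shown at this position, and the entering group brings a hydrogen-bond donor and a defined stereocentre. The printed floor of this step lies within the scatter, so it shows no change beyond the scatter. The true size of the step cannot be read because compound 1 stands at a limit of the assay, not at a number: the limit of > 100000 nM in this assay, at which 1 of the 4 values shown sits.

Open, from the compounds shown here alone, is whether the other configuration of the hydroxy-bearing carbon reads the same in this assay. Also open, going by these compounds, is what an amine or a methoxy group would give in place of that hydroxy group, and whether the same change holds on the chain of compound 2.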